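Removing a Chloro Group from a Potent Hydrazide

The compounds below may be only part of what the source reports. "The series", "measured", "known", "first", "only" and "open" are said of these compounds alone.

Compound 2, `COc1ccc(OC)c(/C=C/C(=O)N/N=C/c2ccc(Cl)cc2)c1`, gives the lowest of the two numbers in a functional assay on NCI-H460 cells (Homo sapiens) for antiproliferative activity, read by sulforhodamine B assay, with a stated time of 48 h (a lower number here means a stronger inhibitor of growth, a higher number a weaker inhibitor of growth), at 119 nM. Compound 1, `COc1ccc(OC)c(/C=C/c2nnc(Nc3ccc(Cl)cc3)o2)c1`, lies far apart in this assay, where compound 1 gives 3770 nM, a gap beyond the usual scatter. Compound 3, `COc1ccc(OC)c(/C=C/C(=O)N/N=C/c2ccccc2)c1`, is not yet measured; it differs from compound 2 by hydrogen in place of chloro on an aromatic carbon. No comparable step has been measured among these compounds, so only a modest step toward a weaker inhibitor is expected: a 2.1-fold higher number from compound 2 to compound 3 (0.32 log units; beyond the scatter). Compound 3 is therefore estimated at 250 nM, within a range from 80 nM to 800 nM.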

Compound 3, concentration for 50% growth inhibition: 2080 nM
Compound 3: middle estimate off by 8.3-fold (0.92 log units), on the low side; the measured number lies above the stated range.
By their numbers in this assay, from the lowest: compound 2; then compounds 3 and 1 (each within the scatter of the next).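

Putting hydrogen in place of chloro on the aromatic carbon gives a 17-fold higher number from compound 2 to compound 3 (1.24 log units; beyond the scatter) in this assay and is the first change at a single place that can be read among these compounds. This one atom, para to a large group, therefore matters greatly to growth inhibition in this pair. No measurement at hand explains the size of this loss.

As far as these compounds go, whether a fluoro, a methoxy or an amine at this place would keep the activity of compound 2 remains open. So does whether chloro matters as much on the core of compound 1.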